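The source may hold more compounds than are shown below. What is called first, only, known or untested is meant among the compounds shown, and "the series" means these compounds.

Working notes on the series. Compound 1 `CCC(C)(C)Cc1c[nH]c(CCc2ccc(-c3ccncc3)cc2)n1` is the reference point; in a functional assay on HEK293 cells for agonist activity at Bombesin receptor subtype-3 (Homo sapiens), read by luminescence and calcium flux, with a stated time of 10 min (on this read-out lower numbers stand for an effect already at smaller amounts and higher numbers for an effect only at larger amounts of compound), compound 1 gives 95 nM. Compound 2 `CCC(C)(C)Cc1c[nH]c(CCc2ccc(-c3ccccc3C(=O)O)cc2)n1` gives 101 nM in this assay, and compound 3 `CCC(C)(C)Cc1c[nH]c(CCc2ccc(-c3ccc(F)cn3)cc2)n1` gives 97 nM. The three numbers lie within the scatter of one another: a 1.1-fold higher number from compound 1 to compound 2 (0.03 log units; within the scatter), a 1.0-fold higher number from compound 1 to compound 3 (0.01 log units; within the scatter), and a 1.0-fold lower number from compound 2 to compound 3 (0.02 log units; within the scatter). Compound 3 therefore stands with the other two, separated from neither by more than the scatter.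

Compound 4 `CCC(C)(C)Cc1c[nH]c(CCc2ccc(-c3csnn3)cc2)n1` differs from compound 3 by 1,2,3-thiadiazol-4-yl in place of 5-fluoropyridin-2-yl on an aromatic carbon. The measured steps that bear on this position all exchanged one pendant aromatic group for another, pyridin-4-yl, 2-carboxyphenyl and 5-fluoropyridin-2-yl, and none of them moved this assay beyond the scatter. Within the data shown here, a five-membered ring with three hetero atoms has no precedent among the three measured compounds, so the expectation rests on the tolerance seen so far rather than on a close analogue. No step beyond the scatter is expected in this assay; the estimated step is a 1.0-fold higher number from compound 3 to compound 4 (0.01 log units; within the scatter). For compound 4 the expected value in this assay is 100 nM, with a range from 40 nM to 250 nM.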

Compound 4, half-maximal effective concentration: 104 nM
Beside the measured number, compound 4's estimate is 1.0-fold (0.02 log units) below it, within the range that was stated.
By their numbers in this assay, from the lowest: compounds 1, 3, 2 and 4 (each within the scatter of the next).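

In this assay, the place on the aromatic carbon para to a large group also takes a five-membered aromatic ring with 3 hetero atoms, with all three new steps staying within the scatter: a 1.1-fold higher number from compound 3 to compound 4 (0.03 log units; within the scatter), a 1.0-fold higher number from compound 2 to compound 4 (0.01 log units; within the scatter) and a 1.1-fold higher number from compound 1 to compound 4 (0.04 log units; within the scatter). Among these compounds, the earlier compounds carried only six-membered aromatic rings here, so the flat picture now extends across a change of ring size and hetero atom content, with sulfur entering for the first time. No measured information is available that explains this lack of response.

As far as these compounds go, all four compounds carry an aromatic ring at this place, so it remains open whether an amine, a longer alkyl chain or a simple hydrogen would be tolerated as well. From the compounds shown here alone, it is also open whether the same tolerance would hold with a change elsewhere in the shared core.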